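Swapping benzyl for benzoyl on an aromatic nitrogen

A few compounds are considered here, and "the series" means these few. Any claim that something is new, unique, unknown or untested is made for them only; others in the source may bear on it.

Measured so far in a functional assay on MDA-MB-231 cells (Homo sapiens) for cytotoxicity, read by MTT assay, with a stated time of 48 h; on this read-out higher numbers stand for weaker inhibition and lower numbers for stronger inhibition:
Compound 1, `O=C1C[C@H](OCc2cn(-c3ccccc3)nn2)[C@H]2CO[C@@H]1O2`: compound 1 gives 25200 nM.
Compound 2, `O=C(O)c1ccc(-n2cc(CO[C@H]3CC(=O)[C@@H]4OC[C@H]3O4)nn2)cc1`: compound 2 gives 23200 nM.
Compound 3, `CC(=O)N(Cc1cn(Cc2ccccc2)nn1)[C@H]1CC(=O)[C@@H]2OC[C@H]1O2`: compound 3 gives only a limit of this assay, > 50000 nM.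

Compounds 1 and 2 share a core and differ only by a carboxy group on an aromatic carbon; the step of a 1.1-fold lower number from compound 1 to compound 2 (0.04 log units; within the scatter) stays within the scatter, so nothing can be read from it. Compound 3 stands apart from both: its result is not a number but the limit of this assay, as described by the limit of > 50000 nM in this assay, at which 1 of the 3 values shown sits, so it sits at the weak edge of what the numbers shown can reach.

Compound 4, `CC(=O)N(Cc1cn(C(=O)c2ccccc2)nn1)[C@H]1CC(=O)[C@@H]2OC[C@H]1O2`, differs from compound 3 by benzoyl in place of benzyl on an aromatic nitrogen. Among the compounds with values here, no measured step concerns this change; the only measured step, a 1.1-fold lower number from compound 1 to compound 2 (0.04 log units; within the scatter), involves a different group at a different place and was within the scatter. With nothing to point the other way, compound 4 is expected to remain at or near the limit, which is an estimated step that the limit leaves unreadable from compound 3 to compound 4. The estimate for compound 4 is 60000 nM, within a range from 20000 nM to 150000 nM.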

Compound 4, half-maximal inhibitory concentration: > 50000 nM
Compound 4 was reported as a limit (the forecaster's own chance of this, stated with the estimate: 70%); the middle value is on the limit's open side.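

Compound 3 and compound 4 are both reported only as limits, so no step between them can be read: the limit of > 50000 nM in this assay, at which 2 of the 4 values shown sit.

The compounds shown leave open whether benzyl or benzoyl on the aromatic nitrogen gives stronger inhibition, and what actual number either compound would reach.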